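The source may report more compounds than this note shows. Statements on the series, on what has been measured and on what is new or still open speak of the compounds shown alone.

Compound 1 `O=S1(=O)Cc2nc(-c3cc(F)c(Cl)cc3F)nc(N3CCC(CO)CC3)c2C1` shows the shared core of this small set. In a functional assay on the whole organism (blood, strain ICR) with Mus musculus as the target, in the glucose tolerance test, with a stated time of 30 min (on this read-out higher numbers stand for an effect only at larger amounts of compound and lower numbers for an effect already at smaller amounts), compound 1 gives 0.3 mg/kg. Compound 2 `NC(=O)CC1CCN(c2nc(-c3cc(F)c(Cl)cc3F)nc3c2CS(=O)(=O)C3)CC1` gives 0.1 mg/kg in this assay, the lowest of the two numbers measured, and the step of a 3.0-fold lower number from compound 1 to compound 2 (0.48 log units; beyond the scatter) describes how far it sits from the other number. Compound 3 `O=C(O)C1CCN(c2nc(-c3cc(F)c(Cl)cc3F)nc3c2CS(=O)(=O)C3)CC1` reaches only a limit of the assay, > 3 mg/kg. Compared with it, an at least 10-fold higher number from compound 1 to compound 3 (1.00 log units; beyond the scatter) and an at least 30-fold higher number from compound 2 to compound 3 (1.47 log units; beyond the scatter), so the carboxy group stands apart from both neighbours.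

Compound 4 `O=S1(=O)Cc2nc(-c3cc(F)c(Cl)cc3F)nc(N3CCC(CCO)CC3)c2C1` has not yet been measured in this assay. It differs from compound 2 by hydroxymethyl in place of carbamoyl on a saturated chain carbon bound to a saturated ring carbon. For the measured compounds named here, the measured step that bears most directly on this change is the one between compound 1 and compound 2, where a hydroxy group was replaced by carbamoyl at the same kind of position and a 3.0-fold lower number from compound 1 to compound 2 (0.48 log units; beyond the scatter). Compound 4 reverses that kind of exchange, one bond further out, so a modest rise in the minimum effective dose is expected, with the step of a 3.0-fold higher number from compound 2 to compound 4 (0.48 log units; beyond the scatter). The carboxy result of compound 3 is not expected to apply, since no acid is formed. Compound 4 is therefore estimated at 0.3 mg/kg, within a range from 0.1 mg/kg to 1 mg/kg.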

Compound 4, minimum effective dose: 1 mg/kg
The estimate for compound 4 lay 3.3-fold (0.52 log units) below the measured number; low and high end bracket the measured number.
By their numbers in this assay, from the lowest: compound 2; then compound 1; then compound 4. At a limit, above all of these: compound 3.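

In this assay, the carbamoyl end of the 4-(carbamoylmethyl)piperidin-1-yl group proves hard to replace, as exchanging it for hydroxymethyl to give the 4-(2-hydroxyethyl)piperidin-1-yl group produces this change: a 10-fold higher number from compound 2 to compound 4 (1.00 log units; beyond the scatter). Chain length also matters with the hydroxy group kept at the end, a comparison that the earlier compounds did not offer: a 3.3-fold higher number from compound 1 to compound 4 (0.52 log units; beyond the scatter). The carboxy group still stands apart, with a step that rests on a limit and not on a number: an at least 3.0-fold lower number from compound 3 to compound 4 (0.47 log units; beyond the scatter).

The compounds shown leave open how a longer chain ending in carbamoyl, or an amine placed on the same saturated chain carbon, would fare in this assay. They also hold no measurement that explains the differences in dose, so these results describe where the effect is gained or lost and not how that happens.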